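This account rests on a few compounds, and the source may have more. Where it says the series, first, only, none or still open, it means among the compounds named here.

Two compounds with a shared core and a thioether-linked heteroaryl group were examined in a functional assay on MCF7 cells (Homo sapiens) for cytotoxicity, read by MTT assay, with a stated time of 72 h; on this read-out lower numbers stand for stronger inhibition and higher numbers for weaker inhibition. In this assay compound 1 `O=c1cc(CSc2nc3ccccc3s2)oc2ccccc12` gives > 25000 nM, which is a limit of the assay rather than a number. Compound 2 `Cc1nnc(SCc2cc(=O)c3ccccc3o2)s1` fares no differently: in this assay compound 2 reaches only > 25000 nM, again a limit. Compound 2 therefore stands at the limit of > 25000 nM in this assay, at which 2 of the 2 values shown sit, so no numerical value places it against compound 1. Compound 3 `Cc1nnc(SCc2cc(=O)c3ccccc3o2)o1` differs from compound 2 by 5-methyl-1,3,4-oxadiazol-2-yl in place of 5-methyl-1,3,4-thiadiazol-2-yl on a sulfur. Going by the values given here, no measured step covers this change, and the pair of limits offers nothing to rank. The step from compound 2 to compound 3 is expected to be a step that the limit leaves unreadable from compound 2 to compound 3, meaning no shift beyond the scatter is anticipated. Compound 3 is accordingly estimated at 35000 nM in this assay, within a range from 10000 nM to 120000 nM, and is most likely to be reported again only as a limit.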

Compound 3, half-maximal inhibitory concentration: > 25000 nM
Compound 3: no number, only a limit; the forecaster's own chance of this, stated with the estimate: 80%; the middle value does not contradict the limit.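

In this assay, going by these compounds alone, compound 2 and compound 3 both stand only as limits, so no step between them can be read: the limit of > 25000 nM in this assay, at which 3 of the 3 values shown sit. The compounds shown leave open how 5-methyl-1,3,4-oxadiazol-2-yl and 5-methyl-1,3,4-thiadiazol-2-yl on a sulfur compare on this read-out.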